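The source may report more compounds than this note shows. Statements on the series, on what has been measured and on what is new or still open speak of the compounds shown alone.

In a functional assay on SW480 cells (Homo sapiens) for antiproliferative activity, read by MTT assay, with a stated time of 48 h (on this read-out lower numbers stand for stronger inhibition and higher numbers for weaker inhibition), compound 1 `CCCCCC(CCO)n1cnc2c(NC)ncnc21` gives only a limit, > 50000 nM. Compound 2 `CCCCCC(CCO)n1cnc2c(N)ncnc21` also gives only a limit, > 50000 nM. Compound 2 therefore has no number of its own and stands at the limit of > 50000 nM in this assay, at which 2 of the 2 values shown sit.

Compound 3 `CCCCCCCCCC(CCO)n1cnc2c(N)ncnc21` lengthens the chain of compound 2: butyl in place of hydrogen on a saturated chain carbon, six bonds along the chain from an aromatic nitrogen. This places butyl in place of hydrogen on a saturated chain carbon, six bonds along the chain from an aromatic nitrogen.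

Within the data shown here, only one measured step is available, a step that the two limits leave unreadable from compound 1 to compound 2. It involves a different part of the molecule and has no readable size, so it provides no measure for a change in the chain. Among the measured compounds shown here, no measured step shows what added chain length does in this assay, and any expectation must rest on the structural change alone. A modest gain in inhibition is tentatively expected, although another limit would be no surprise. The expected change is an at least 1.6-fold lower number from compound 2 to compound 3 (0.22 log units; that floor lies within the scatter), which remains an estimate with little support. For compound 3, the estimated value is 30000 nM, with an expected range of 9000 nM to 90000 nM.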

Compound 3, half-maximal inhibitory concentration: 6030 nM
Compound 3: middle estimate off by 5.0-fold (0.70 log units), on the high side; the whole stated range lies above it.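

In this assay, butyl in place of hydrogen on a saturated chain carbon, six bonds along the chain from an aromatic nitrogen, yields the only real number among the compounds shown, with an at least 8.2-fold lower number from compound 2 to compound 3 (0.91 log units; beyond the scatter). Among these compounds, this is the first readable sign that the chain responds to a change in this assay, whereas the earlier step, hydrogen in place of methyl on a nitrogen on an aromatic ring, cannot be read. Compound 2 gives only a limit, so the printed size of the step is a floor and the true gap may be larger: the limit of > 50000 nM in this assay, at which 2 of the 3 values shown sit.

On these data alone, a single step sets no trend, and it remains open whether a longer chain than that of compound 3 would lower the number further or whether the gain would level off or reverse. As far as these compounds go, it is also open whether methyl on the nitrogen, as in compound 1, would matter once the longer chain is in place, and whether an amine or a carboxylic acid in place of the hydroxyl would keep the inhibition seen with compound 3.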